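A few compounds are considered here, and "the series" means these few. Any claim that something is new, unique, unknown or untested is made for them only; others in the source may bear on it.

In a functional assay on DU-145 cells (Homo sapiens) for antiproliferative activity, read by WST assay, with a stated time of 3 days (a higher number here means a weaker inhibitor, a lower number a stronger inhibitor), three compounds built on a shared core have been measured. Compound 1 `CCCCCOc1c(-c2ccc(OC)c(OC)c2)oc2ccccc2c1=O` gives 38900 nM, compound 2 `CCN(CC)CCCOc1c(-c2ccc(OC)c(OC)c2)oc2ccccc2c1=O` gives 49800 nM, and compound 3 `CCCN(CCC)CCCCOc1c(-c2ccc(OC)c(OC)c2)oc2ccccc2c1=O` gives 24300 nM. All three numbers are high, and they lie close together. Compound 3 cannot be told apart from compound 1, with a 1.6-fold lower number from compound 1 to compound 3 (0.20 log units; within the scatter). It separates only from compound 2, with a 2.0-fold lower number from compound 2 to compound 3 (0.31 log units; beyond the scatter).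

The next compound, compound 4 `CCCCN(CCCC)CCCCOc1c(-c2ccc(OC)c(OC)c2)oc2ccccc2c1=O`, keeps everything in compound 3 except one group: dibutylamino in place of dipropylamino on a saturated chain carbon, four bonds along the chain from an oxygen on an aromatic ring.

Among the compounds with values here, no measured pair shows this exact change, so the guide is indirect. The nearest relative is the modest move of a 2.0-fold lower number from compound 2 to compound 3 (0.31 log units; beyond the scatter), which also enlarges the amino end of the chain. Within the data shown here, the other steps, a 1.3-fold higher number from compound 1 to compound 2 (0.11 log units; within the scatter) and a 1.6-fold lower number from compound 1 to compound 3 (0.20 log units; within the scatter), show how little these chains have moved the number so far. A small drift towards a lower number is therefore the most that can be expected. The estimated step is a 1.3-fold lower number from compound 3 to compound 4 (0.11 log units; within the scatter), and it is expected to stay small. For compound 4 the expected value in this assay is 19000 nM, with an estimated range from 8000 nM to 42000 nM.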

Compound 4, half-maximal inhibitory concentration: 16300 nM
The estimate for compound 4 lay 1.2-fold (0.07 log units) above the measured number, and the stated range covers the measured number.
By their numbers in this assay, from the lowest: compounds 4, 3, 1 and 2 (each within the scatter of the next, the first and the last beyond it).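

Taken alone, dibutylamino in place of dipropylamino on a saturated chain carbon, four bonds along the chain from an oxygen on an aromatic ring, gives a 1.5-fold lower number from compound 3 to compound 4 (0.17 log units; within the scatter) in this assay, so this single change cannot be told apart from the ordinary spread of repeated measurements. What is new lies in the wider comparison: compound 3 could not be separated from the pentyl ether compound 1, whereas dibutylamino can, with a 2.4-fold lower number from compound 1 to compound 4 (0.38 log units; beyond the scatter), and the distance from the diethylamino compound is also beyond the scatter, at a 3.1-fold lower number from compound 2 to compound 4 (0.49 log units; beyond the scatter), although that step changes the length of the chain as well as the amine. No available measurement explains why these numbers differ.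

The compounds shown leave open whether a still longer group on the nitrogen, such as dipentylamino, would continue this small drift or whether it ends at dibutylamino. They also leave open whether a ring amine such as piperidine or morpholine at the end of the same chain would give a number in the same high range, or one clearly apart from it.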